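The source may hold more compounds than are shown below. What is called first, only, known or untested is meant among the compounds shown, and "the series" means these compounds.

Compound 1, `COc1ccccc1C(=O)Nc1cccc(-c2oc3cc(-c4ccc(F)cc4)ccc3c(=O)c2O)c1`, gives 9050 nM in a functional assay on HCC1937 cells (Homo sapiens) for antiproliferative activity, read by CCK-8 assay, with a stated time of 72 h; on this read-out lower numbers stand for stronger inhibition and higher numbers for weaker inhibition.
Compound 2, `Cc1ccccc1C(=O)Nc1cccc(-c2oc3cc(-c4ccc(F)cc4)ccc3c(=O)c2O)c1`, gives 9900 nM in this assay.
Compound 3, `O=C(Nc1cccc(-c2oc3cc(-c4ccc(F)cc4)ccc3c(=O)c2O)c1)c1ccc(Br)cc1`, gives 8630 nM in this assay.

All three share the same core and differ only in the aromatic ring attached to the carbonyl carbon of the amide. Compound 2 stands in a cluster with the other two: the step of a 1.1-fold higher number from compound 1 to compound 2 (0.04 log units; within the scatter) and the step of a 1.1-fold lower number from compound 2 to compound 3 (0.06 log units; within the scatter) both lie within the scatter, so its number cannot be told apart from those of compound 1 and compound 3.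

Compound 4, `O=C(Nc1cccc(-c2oc3cc(-c4ccc(F)cc4)ccc3c(=O)c2O)c1)c1cc(F)cc(F)c1`, has not yet been measured in this assay. It differs from compound 2 in one place: 3,5-difluorophenyl in place of 2-methylphenyl on a carbonyl carbon

The measured steps that bear on this change all swap the same ring on the carbonyl carbon. The step of a 1.1-fold lower number from compound 2 to compound 3 (0.06 log units; within the scatter) and the step of a 1.0-fold lower number from compound 1 to compound 3 (0.02 log units; within the scatter) each exchange one substituted phenyl for another, and each stays within the scatter, as does a 1.1-fold higher number from compound 1 to compound 2 (0.04 log units; within the scatter). Nothing among these three compounds suggests that varying this ring moves the number beyond the scatter, so no step beyond it is expected in this assay for compound 4 either.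

Compound 4 is therefore expected to give about 9500 nM, with a range from 5000 nM to 19000 nM. This estimate implies an expected step of a 1.0-fold lower number from compound 2 to compound 4 (0.02 log units; within the scatter).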

Compound 4, half-maximal inhibitory concentration: 2070 nM
The estimate for compound 4 lay 4.6-fold (0.66 log units) above the measured number, outside the stated range (below it).
By their numbers in this assay, from the lowest: compound 4; then compounds 3, 1 and 2 (each within the scatter of the next).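

The ring on the carbonyl carbon of the amide is not a silent position in this assay, even though swapping among the 2-methoxyphenyl, 2-methylphenyl and 4-bromophenyl rings left the number within the scatter. With 3,5-difluorophenyl on that carbon, the numbers move beyond the scatter in all three comparisons, each modest in size: a 4.8-fold lower number from compound 2 to compound 4 (0.68 log units; beyond the scatter) and a 4.2-fold lower number from compound 3 to compound 4 (0.62 log units; beyond the scatter) and a 4.4-fold lower number from compound 1 to compound 4 (0.64 log units; beyond the scatter) in turn, which makes compound 4 the most potent of these four in this assay. These compounds show that one phenyl ring can differ from the others at this position, but no data shown say why this ring does so.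

As far as these compounds go, it remains open whether the shift needs both fluorines, and a phenyl ring with a single fluorine, or one with chlorine in place of each fluorine, would help to separate these possibilities. Also open, from the compounds shown here alone, is how the position responds to something other than a substituted phenyl, such as a pyridine ring, or to a phenyl ring carrying an amine or a carboxylic acid.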